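Aryloxy swap on the shared core: metabolic stability notes

A few compounds are considered here, and "the series" means these few. Any claim that something is new, unique, unknown or untested is made for them only; others in the source may bear on it.

Compound 1 `Cn1cc(/C=C/C(=O)NS(=O)(=O)c2cc(F)c(F)cc2F)c2c(Oc3ccc4ccccc4c3)cccc21` gives 32% in an ADME assay on microsomes from liver (Rattus norvegicus) for metabolic stability, with a stated time of 30 min, tested at 5 uM (a higher number here means that more of the compound is left, a lower number that less of the compound is left), the lowest of the three numbers shown, though compound 2 `Cn1cc(/C=C/C(=O)NS(=O)(=O)c2cccc(Cl)c2)c2c(Oc3ccc4ccccc4c3)cccc21` at 33.3% and compound 3 `Cn1cc(/C=C/C(=O)NS(=O)(=O)c2ccc(F)c(F)c2)c2c(Oc3ccc(Cl)cc3F)cccc21` at 40% both lie within the scatter of it. Compound 4 `Cn1cc(/C=C/C(=O)NS(=O)(=O)c2cc(F)c(F)cc2F)c2c(Oc3ccc(Cl)cc3Cl)cccc21` differs from compound 1 by 2,4-dichlorophenyl in place of naphthalen-2-yl on an oxygen on an aromatic ring. Within the data shown here, no measured step changes this place alone: a number 1.3 percentage points higher from compound 1 to compound 2 (within the scatter) concerns the sulfonyl side, and compound 3 carries a different aryloxy group together with a different sulfonyl group, so its number set against compound 1 shows only two values within the scatter. On this basis no step beyond the scatter is expected, and a number 4 percentage points higher from compound 1 to compound 4 (within the scatter) is the estimate. Compound 4 is therefore expected near 36%, within 22% to 50%.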

Compound 4, percent of the compound remaining: 39.1%
The estimate for compound 4 lay 3.1 percentage points below the measured number; low and high end bracket the measured number.
By their numbers in this assay, from the lowest: compounds 1, 2, 4 and 3 (each within the scatter of the next).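

Within this assay, the oxygen-linked aryl group now has a step of its own, a number 7.1 percentage points higher from compound 1 to compound 4 (within the scatter), with 2,4-dichlorophenyl in place of naphthalen-2-yl. Exchanging the two-ring group for the one-ring dichlorinated group therefore does not separate the two compounds in this read-out. No available evidence bears on this result.

Still open, from the compounds shown here alone, is whether an aryl group carrying an amine or a carboxylic acid, or a longer alkyl chain on the same oxygen, would give a step beyond the scatter. Going by these compounds, whether this change reads the same alongside other sulfonyl groups also remains open.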